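Hydroxyphenyl position in two related enone series

This account rests on a few compounds, and the source may have more. Where it says the series, first, only, none or still open, it means among the compounds named here.

Measured so far:
- compound 1, `O=C1/C(=C/c2ccccc2)CCC/C1=C\c1ccc(O)cc1`: 53%
- compound 2, `O=C(/C=C(O)/C=C/c1ccc(O)cc1)c1cc(Cl)ccc1O`: 45.3%
- compound 3, `O=C1/C(=C/c2ccccc2)CCC/C1=C\c1cccc(O)c1`: 65.1%

In an assay on isolated protein for inhibition of Alpha glucosidase (Homo sapiens), with stated times of 5 min and 15 min, tested at 50 uM (on this read-out higher numbers stand for more inhibition at the one concentration tested (going by the name of the read-out) and lower numbers for less inhibition), compound 1 gives 53% and compound 3 gives 65.1%. Among the compounds with values here, the two differ by 3-hydroxyphenyl in place of 4-hydroxyphenyl on a double-bonded chain carbon bound to a double-bonded ring carbon, and the step of a number 12.1 percentage points higher from compound 1 to compound 3 (beyond the scatter) is the one change measured twice in this set when compound 4 is included. Compound 2 gives 45.3% in this assay; compound 2 and compound 1 are within the scatter of each other, and the difference between the two cores is not broken down here.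

Compound 4, `O=C(/C=C(O)/C=C/c1cccc(O)c1)c1cc(Cl)ccc1O`, is not yet measured. It differs from compound 2 by 3-hydroxyphenyl in place of 4-hydroxyphenyl on a double-bonded chain carbon bound to a double-bonded chain carbon. This is the same kind of change as from compound 1 to compound 3, but not the same: there the place is on a double-bonded chain carbon bound to a double-bonded ring carbon, here on a double-bonded chain carbon bound to a double-bonded chain carbon. Whether the step carries over from one core to the other rests on a single measured pair, so the expectation is tentative. Within the data shown here, a step of about a number 9.7 percentage points higher from compound 2 to compound 4 (within the scatter) is expected from compound 2 to compound 4 because the only measured instance, a number 12.1 percentage points higher from compound 1 to compound 3 (beyond the scatter), was modest and beyond the scatter. For compound 4 an inhibition of 55% in this assay is estimated, expected to fall between 40% and 70%.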

Compound 4, a percentage reported as inhibition, at one concentration (the size of the read-out at that concentration, not a potency): 62.4%
Compound 4: the middle estimate sits 7.4 percentage points below what was measured, and the stated range covers the measured number.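

On the second core, 3-hydroxyphenyl in place of 4-hydroxyphenyl, on a double-bonded chain carbon bound to a double-bonded chain carbon, gives a number 17.1 percentage points higher from compound 2 to compound 4 (beyond the scatter) in this assay. Set beside the earlier step on the first core, this one points the same way and cannot be told apart from it in size, so within this series the change carries from one core to the other: the same change on two cores in this assay, a number 12.1 percentage points higher (beyond the scatter) from compound 1 to compound 3 and a number 17.1 percentage points higher (beyond the scatter) from compound 2 to compound 4, 5 percentage points apart, within the scatter of two such steps. Within the data shown here, this rests on only two matched pairs, each read at a single concentration in one assay, so it shows neither a difference in potency nor that the step would hold on any core beyond these two, and it gives no reason why the 3-hydroxyphenyl compounds read higher.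

What the compounds shown leave open is whether a methoxy group, an amine or a carboxylic acid in place of the hydroxyl on this phenyl ring would keep the inhibition seen with 3-hydroxyphenyl. Also open, going by these compounds, is whether the step would persist on a third core, or on a version of the second core without its chlorine.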